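Swapping the Amide Cap: A Benzoyl Variant of Compound 2

The source may report more compounds than this note shows. Statements on the series, on what has been measured and on what is new or still open speak of the compounds shown alone.

Compound 2 `CN(C(=O)C(C)(C)C)c1ccc2[nH]c(-c3n[nH]c4ccccc34)cc2n1` carries a tert-butyl group on the carbonyl carbon of its amide. Going by the values given here, in a functional assay on HCT-116 cells (Homo sapiens) for antiproliferative activity, read by MTT assay, with a stated time of 72 h (a higher number here means a weaker inhibitor, a lower number a stronger inhibitor), compound 2 gives 18000 nM, the highest of the two numbers known so far. Its nearest neighbour is compound 1 `CC(=O)N(C)c1ccc2[nH]c(-c3n[nH]c4ccccc34)cc2n1`, which in this assay gives 14800 nM; the step of a 1.2-fold higher number from compound 1 to compound 2 (0.09 log units; within the scatter) lies within the scatter, so the two compounds cannot be told apart on these data. Compound 3 `CN(C(=O)c1ccccc1)c1ccc2[nH]c(-c3n[nH]c4ccccc34)cc2n1` has not yet been measured. It differs from compound 2 by phenyl in place of tert-butyl on a carbonyl carbon. Among the compounds with values here, the only measured step that bears on this position is a 1.2-fold higher number from compound 1 to compound 2 (0.09 log units; within the scatter), and it changed little. The expected step is therefore small as well, with no clear direction: a 1.2-fold lower number from compound 2 to compound 3 (0.08 log units; within the scatter). Compound 3 is expected to give about 15000 nM in this assay, within a range from 6000 nM to 40000 nM.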

Compound 3, half-maximal inhibitory concentration: 10600 nM
Compound 3: the middle estimate sits 1.4-fold (0.15 log units) above what was measured; the range from low to high includes it.
By their numbers in this assay, from the lowest: compounds 3, 1 and 2 (each within the scatter of the next).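

With phenyl on the carbonyl carbon, the amide now carries an aromatic ring rather than an open carbon group, yet in this assay the number does not separate from those of the other two compounds (a 1.7-fold lower number from compound 2 to compound 3 (0.23 log units; within the scatter); a 1.4-fold lower number from compound 1 to compound 3 (0.14 log units; within the scatter)). Both steps lie within the scatter, so methyl, tert-butyl and phenyl cannot be told apart at this position, and compound 3 cannot be ranked against compound 1 or compound 2. No measurement on hand offers an explanation for this flat result.

Still open, as far as these compounds go, is whether a group with atoms other than carbon, such as an amine or a carboxylic acid at the end of a longer chain, would give a step beyond the scatter. The same question applies to a phenyl ring bearing a methoxy group.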